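This account rests on a few compounds, and the source may have more. Where it says the series, first, only, none or still open, it means among the compounds named here.

In a functional assay on A549 cells (Homo sapiens) for antiproliferative activity, read by MTT assay, with a stated time of 48 h (a lower number here means a stronger inhibitor, a higher number a weaker inhibitor), compound 3 `COc1ccccc1-n1nncc1CN1C(=O)C2(C(C#N)=C(N)Oc3c(N)cc4nc5ccccc5nc4c32)c2ccccc21` gives 37500 nM, the highest of the three measured numbers. Compound 1 `Cc1cccc(-n2nncc2CN2C(=O)C3(C(C#N)=C(N)Oc4c(N)cc5nc6ccccc6nc5c43)c3ccccc32)c1` gives 12300 nM, and compound 2 `N#CC1=C(N)Oc2c(N)cc3nc4ccccc4nc3c2C12C(=O)N(Cc1cnnn1-c1ccccc1Br)c1ccccc12` gives 27400 nM. The step from compound 1 to compound 3 was a 3.0-fold higher number from compound 1 to compound 3 (0.48 log units; beyond the scatter), the step from compound 1 to compound 2 was a 2.2-fold higher number from compound 1 to compound 2 (0.35 log units; beyond the scatter), and the step from compound 2 to compound 3 was a 1.4-fold higher number from compound 2 to compound 3 (0.14 log units; within the scatter).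

Compound 4 `CCc1cccc(CC)c1-n1nncc1CN1C(=O)C2(C(C#N)=C(N)Oc3c(N)cc4nc5ccccc5nc4c32)c2ccccc21` carries the change (2,6-diethylphenyl in place of 2-methoxyphenyl on an aromatic nitrogen). Both measured exchanges of the aryl group on this ring nitrogen that started from compound 1 raised the number modestly, while the exchange between compound 2 and compound 3 stayed within the scatter. Among the compounds with values here, no measured pair shows a phenyl bearing two ethyl groups, so the bearing of these steps on compound 4 is indirect. The estimated step of a 1.2-fold higher number from compound 3 to compound 4 (0.08 log units; within the scatter) is expected to remain within the scatter, with a wide uncertainty. The estimated value for compound 4 is 45000 nM, within a range from 15000 nM to 130000 nM.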

Compound 4, half-maximal inhibitory concentration: > 50000 nM
Compound 4 ended at the assay's limit; the forecaster's own chance of this, stated with the estimate: 15%; at least 1.1-fold (0.04 log units) between middle value and limit.
By their numbers in this assay, from the lowest: compound 1; then compounds 2 and 3 (each within the scatter of the next). At a limit, above all of these: compound 4.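

In this assay, compound 4 gives a limit of the assay and not a number: the limit of > 50000 nM in this assay, at which 1 of the 4 values shown sits. Against the 3-methylphenyl group, the 2,6-diethylphenyl group on this aromatic nitrogen gives an at least 4.0-fold higher number from compound 1 to compound 4 (0.60 log units; beyond the scatter), so this exchange is at least as large as either measured exchange from compound 1. Against the other two aryl groups the floors settle no order, with an at least 1.3-fold higher number from compound 3 to compound 4 (0.12 log units; that floor lies within the scatter) and an at least 1.8-fold higher number from compound 2 to compound 4 (0.26 log units; that floor lies within the scatter).

The compounds shown leave open how far the true number of compound 4 lies past its limit, so the full size of all three steps stays unknown. They also leave open where a phenyl with a single ethyl group, or a phenyl carrying an amine, would fall on this nitrogen.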